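Swapping Two Methyls for One Fluorine on the Aryl Ring

The compounds below may be only part of what the source reports. "The series", "measured", "known", "first", "only" and "open" are said of these compounds alone.

Compound 3 `COC(=O)C1=C(C)N=C(C)/C(=C(\O)OC)C1c1cc(C)ccc1C` gives 100 nM in a functional assay (muscle tissue) with Cavia porcellus as the target (on this read-out higher numbers stand for an effect only at larger amounts of compound and lower numbers for an effect already at smaller amounts), the second highest of the three numbers measured. Compound 1 `COC(=O)C1=C(C)N=C(C)/C(=C(\O)OC)C1c1cccc(C)c1` gives 110 nM, and compound 2 `CCc1ccccc1C1C(C(=O)OC)=C(C)N=C(C)/C1=C(\O)OC` gives 6.46 nM. Among the steps, one was a 1.1-fold lower number from compound 1 to compound 3 (0.04 log units; within the scatter) (methyl in place of hydrogen on an aromatic carbon), whereas a 17-fold lower number from compound 1 to compound 2 (1.23 log units; beyond the scatter) and a 15-fold higher number from compound 2 to compound 3 (1.19 log units; beyond the scatter) were both large. Compound 4 `COC(=O)C1=C(C)N=C(C)/C(=C(\O)OC)C1c1cccc(F)c1` differs from compound 3 in that (3-fluorophenyl in place of 2,5-dimethylphenyl on a saturated ring carbon). Among the compounds with values here, no measured step puts a fluorine on this ring; the only change confined to substituents on the aryl ring, a 1.1-fold lower number from compound 1 to compound 3 (0.04 log units; within the scatter), stayed within the scatter, while the large steps all involved the 2-ethylphenyl of compound 2. The expected step is therefore no change at the digits printed from compound 3 to compound 4 (within the scatter), within the scatter. Compound 4 is estimated at 100 nM, with a range from 30 nM to 400 nM.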

Compound 4, half-maximal effective concentration: 20.9 nM
Estimate against measurement, compound 4: 4.8-fold (0.68 log units) above; the measured number lies below the stated range.
By their numbers in this assay, from the lowest: compound 2; then compound 4; then compounds 3 and 1 (each within the scatter of the next).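

Unlike the added methyl between the earlier compounds, a change on the aryl ring that involves no 2-ethylphenyl does move the number in this assay: fluoro in place of methyl gives a 5.3-fold lower number from compound 1 to compound 4 (0.72 log units; beyond the scatter), and 3-fluorophenyl in place of 2,5-dimethylphenyl gives a 4.8-fold lower number from compound 3 to compound 4 (0.68 log units; beyond the scatter). Even so, 3-fluorophenyl does not match 2-ethylphenyl, with a 3.2-fold higher number from compound 2 to compound 4 (0.51 log units; beyond the scatter). Nothing given here explains these steps. On these data alone, it remains open whether chlorine or a methoxy group in place of the fluorine would give a number like that of compound 4.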